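This account rests on a few compounds, and the source may have more. Where it says the series, first, only, none or still open, it means among the compounds named here.

Three compounds sharing one core have entries in a functional assay on HCT-116 cells (Homo sapiens) for cytotoxicity, read by MTT assay, with a stated time of 24 h (on this read-out lower numbers stand for stronger inhibition and higher numbers for weaker inhibition), but only two of them carry a number. Compound 1 (`COc1ccc(/C=C\C(=O)O)c(OCc2cn(-c3ccc(NC(C)=O)cc3)nn2)c1CC=C(C)C`) is entered as "not determined" (no result reported) with no result reported. Compound 2 (`COc1ccc(/C=C\C(=O)O)c(OCc2cn(-c3ccc(NC(=O)c4ccccc4)cc3)nn2)c1CC=C(C)C`) gave 16400 nM and compound 3 (`COc1ccc(/C=C\C(=O)O)c(OCc2cn(-c3cccc(C#N)c3)nn2)c1CC=C(C)C`) gave 35300 nM as the higher of the two numbers, and its gap to compound 2 lies beyond the usual scatter.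

Compound 4 (`COc1ccc(/C=C\C(=O)O)c(OCc2cn(-c3cccnc3Cl)nn2)c1CC=C(C)C`) has not yet been measured. It carries 2-chloropyridin-3-yl in place of the 3-cyanophenyl of compound 3 on an aromatic nitrogen of a five-membered aromatic ring with 3 nitrogen (2-chloropyridin-3-yl in place of 3-cyanophenyl on an aromatic nitrogen). For the measured compounds named here, no two measured compounds differ in one place only, so no direct step is available as a guide. Going by the values given here, the only frame is the pair of numbers, with compound 2 at 16400 nM and compound 3 at 35300 nM as its two ends. On that thin basis, no step beyond the scatter is expected in this assay and neither direction is favoured. The estimated change is small (a 1.2-fold lower number from compound 3 to compound 4 (0.07 log units; within the scatter)). Compound 4 is expected at 30000 nM within an estimated range (13000 nM to 65000 nM).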

Compound 4, half-maximal inhibitory concentration: 23000 nM
Compound 4: the middle estimate sits 1.3-fold (0.12 log units) above what was measured; the measured number falls inside the stated range.
By their numbers in this assay, from the lowest: compounds 2, 4 and 3 (each within the scatter of the next, the first and the last beyond it).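

For the compounds shown here, on the aromatic nitrogen of the five-membered aromatic ring with 3 nitrogen, putting 2-chloropyridin-3-yl in place of 3-cyanophenyl gives a 1.5-fold lower number from compound 3 to compound 4 (0.19 log units; within the scatter) in this assay, and this is the first step in the set that changes one place only. At this position, then, a six-membered aromatic ring of carbon only that carries a nitrile and a six-membered aromatic ring with 1 hetero atom that carries chlorine cannot be told apart on this read-out, even though the two groups differ in ring and substituent alike. No measurement is at hand that would account for this result.

The compounds shown leave open whether any group on this nitrogen would move the number beyond the scatter from compound 3, for example an unsubstituted phenyl, a phenyl ring carrying an amine, or a plain butyl chain. They also leave open whether a methyl ester in place of the carboxylic acid of the shared core would change the reading in this assay.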